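Stereochemical inversion of a silyl-protected bicyclic acetate

A few compounds are considered here, and "the series" means these few. Any claim that something is new, unique, unknown or untested is made for them only; others in the source may bear on it.

Measured compounds:
compound 1, `CC(=O)OC1OC=CC2C1CC[C@H]2O`, 18000 nM in a functional assay on SW1573 cells (Homo sapiens) for antiproliferative activity, read by sulforhodamine B assay, with a stated time of 48 h; on this read-out lower numbers stand for stronger inhibition of growth and higher numbers for weaker inhibition of growth
compound 2, `CC(=O)O[C@@H]1OC=C[C@@H]2[C@H]1[C@@H](C)C[C@H]2O[Si](c1ccccc1)(c1ccccc1)C(C)(C)C`, 590 nM

Compound 2 gives the lowest number of the two measured compounds in this assay, and compound 1 gives a higher number, a gap beyond the usual scatter. For the measured compounds named here, no single-change step between measured compounds is available, so the two values of compound 1 and compound 2 say only that the two structures differ at several places at once and that the numbers differ.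

Compound 3, `CC(=O)O[C@H]1OC=C[C@H]2[C@@H]1[C@H](C)C[C@H]2O[Si](c1ccccc1)(c1ccccc1)C(C)(C)C`, is a stereoisomer of compound 2: the two compounds have the same atoms and bonds and differ only in configuration as drawn: 4 of 5 stereo elements differ; a stereocentre at a saturated ring carbon is drawn S in compound 2 and R in compound 3; a stereocentre at a saturated ring carbon is drawn R in compound 2 and S in compound 3; a stereocentre at a saturated ring carbon is drawn R in compound 2 and S in compound 3; a stereocentre at a saturated ring carbon is drawn S in compound 2 and R in compound 3. Inversion of most of the ring stereocentres is a change of unknown size here, since no measured pair shows such a step. A weakening beyond the scatter is expected for compound 3, with wide uncertainty, as a 2.5-fold higher number from compound 2 to compound 3 (0.41 log units; beyond the scatter). The estimate for compound 3 in this assay is 1500 nM, within a range of 400 nM to 6000 nM.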

Compound 3, concentration for 50% growth inhibition: 430 nM
Beside the measured number, compound 3's estimate is 3.5-fold (0.54 log units) above it; the range from low to high includes it.
By their numbers in this assay, from the lowest: compounds 3 and 2 (each within the scatter of the next); then compound 1.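

In this assay, inverting 4 of the 5 stereo elements gives a 1.4-fold lower number from compound 2 to compound 3 (0.14 log units; within the scatter), so this change of configuration leaves the growth-inhibition number unchanged within the scatter. For the compounds shown here, this is the first comparison that can be read as a single change, as compounds 1 and 2 differ at several places at once. It rests on one fact: the fact that compounds 2 and 3 differ only in the configuration as drawn.

The compounds shown do not tell how much the silyl ether, the methyl group or the acetate each contributes to the numbers, and they do not separate the four inverted stereocentres from one another. Going by these compounds, it also remains open how the number would respond to an amine or a longer alkyl chain in place of the silyl ether.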